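This account rests on a few compounds, and the source may have more. Where it says the series, first, only, none or still open, it means among the compounds named here.

Compound 1 `CCc1ncncc1-c1nc2cc(F)c(F)cc2n1C1CC1` and compound 2 `Fc1cc2nc(-c3cncnc3C3CC3)n(C3CC3)c2cc1F` share one core and differ only at a single aromatic carbon. In an assay on cells for inhibition of cytochrome P450 11B2, mitochondrial (Homo sapiens), read by HPLC, with a stated time of 90 min (on this read-out higher numbers stand for weaker inhibition and lower numbers for stronger inhibition), compound 1 gives 8 nM, while compound 2 gives 172 nM. Among the compounds with values here, the change of cyclopropyl in place of ethyl on an aromatic carbon brought a 22-fold higher number from compound 1 to compound 2 (1.33 log units; beyond the scatter), so compound 2 stands with the highest of the two numbers measured so far, its nearest neighbour being compound 1.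

Compound 3 `N#Cc1ncncc1-c1nc2cc(F)c(F)cc2n1C1CC1` alters the same position again: cyano in place of cyclopropyl on an aromatic carbon. Within the data shown here, only the step from compound 1 to compound 2 touches this position, and it was large; no measured step introduces a cyano group, so its direction here is not known from these data. Since exchanging the group at this carbon has already shifted this assay strongly, compound 3 is expected to move clearly as well, and a return towards the lower number of compound 1 is judged more likely than a further rise, giving an expected 4.3-fold lower number from compound 2 to compound 3 (0.63 log units; beyond the scatter). Compound 3 is therefore estimated at 40 nM, with a range from 8 nM to 250 nM.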

Compound 3, half-maximal inhibitory concentration: 13 nM
The estimate for compound 3 lay 3.1-fold (0.49 log units) above the measured number, and the stated range covers the measured number.
By their numbers in this assay, from the lowest: compounds 1 and 3 (each within the scatter of the next); then compound 2.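

In this assay cyano in place of cyclopropyl gave a 13-fold lower number from compound 2 to compound 3 (1.12 log units; beyond the scatter) and so showed that the high number of compound 2 does not extend to every exchange at this carbon next to the ring nitrogen. Cyano in place of ethyl gave a 1.6-fold higher number from compound 1 to compound 3 (0.21 log units; within the scatter) and so lies within the scatter, which means that these two groups cannot be told apart here, although only cyano has a triple bond, while cyclopropyl alone stands apart from both. No measurement available here accounts for this difference.

The compounds shown leave open whether methyl, a longer chain such as propyl, an amine or a carboxylic acid at this carbon would fall with compound 1 and compound 3 or with compound 2. They also leave open whether the gap persists when the other cyclopropyl, on the shared core, is replaced.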